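A few compounds are considered here, and "the series" means these few. Any claim that something is new, unique, unknown or untested is made for them only; others in the source may bear on it.

Three measured compounds are in hand:

compound 1, `CC1(C)C[C@H](O)C[C@](C)(CNc2nc3ccccc3s2)C1`, 36800 nM
compound 2, `CC1(C)C[C@H](O)C[C@](C)(CNc2nc3ccc(Cl)cc3s2)C1`, 4200 nM
compound 3, `CC1(C)C[C@H](O)C[C@](C)(CNc2ccccc2)C1`, 37000 nM

All three were read in an ADME assay on MDCK cells (Canis lupus familiaris) for cytotoxicity, read by MTT assay, with a stated time of 3 days; a higher number here means that more compound is tolerated, a lower number that less compound is tolerated. Compound 1 and compound 3 give numbers that lie within the scatter of each other, so nothing separates them in this assay; compound 2 stands apart from both. Among the compounds with values here, the one counted step among the measured compounds runs from compound 1 to compound 2: chloro in place of hydrogen on an aromatic carbon. It gave an 8.8-fold lower number from compound 1 to compound 2 (0.94 log units; beyond the scatter). Within the data shown here, compound 3 differs from compound 1 in its core, and that difference is not broken down here; the two numbers show only that compound 3 gives 37000 nM while compound 1 gives 36800 nM.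

Compound 4, `CC1(C)C[C@H](O)C[C@](C)(CNc2ccc(Cl)cc2)C1`, has not yet been measured. It arises from compound 3 by chloro in place of hydrogen on an aromatic carbon. This is the same kind of change as from compound 1 to compound 2, but the surroundings differ: in compound 2 the six-membered aromatic ring of carbon only is part of a fused or bridged system of two rings, with the chloro meta to a fused ring and para to a fused ring, whereas in compound 4 the ring is not fused and the chloro is para to a large group.

With a single example of the change in hand, compound 4 is expected to give 8000 nM in this assay, which would mean a 4.6-fold lower number from compound 3 to compound 4 (0.67 log units; beyond the scatter). For compound 4 the expected range runs from 3000 nM to 25000 nM. This expectation rests on the one step shown, an 8.8-fold lower number from compound 1 to compound 2 (0.94 log units; beyond the scatter), taken as a guide for a change of the same kind on the core of compound 3, with the range kept wide since the core is different.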

Compound 4, half-maximal cytotoxic concentration: 8100 nM
Compound 4: the middle estimate sits 1.0-fold (0.01 log units) below what was measured; the range from low to high includes it.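

In this assay, chloro in place of hydrogen on an aromatic carbon, para to a large group, gave a 4.6-fold lower number from compound 3 to compound 4 (0.66 log units; beyond the scatter), so the number also falls on this second core. Set beside the earlier step, the two sizes cannot be told apart, and the change carries over between these two cores in both direction and approximate size: the same change on two cores in this assay, an 8.8-fold lower number (0.94 log units; beyond the scatter) from compound 1 to compound 2 and a 4.6-fold lower number (0.66 log units; beyond the scatter) from compound 3 to compound 4, 1.9-fold (0.28 log units) apart, within the scatter of two such steps. Within the data shown here, this is only one pair of steps, however, with the chloro in different surroundings in each, so it does not show that the change would behave the same way on any further core, and it gives no reason why the number falls.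

The compounds shown leave open whether the lower number is particular to chloro or would also follow from another group at the same place, such as fluoro, methoxy, an amine or a carboxylic acid. They also leave open what chloro would do at another place on the aromatic ring, and how the step would fare if the hydroxyl group or the methyl groups of the shared part were replaced.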